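Exchanging a Whole Group on Compound 1

This account rests on a few compounds, and the source may have more. Where it says the series, first, only, none or still open, it means among the compounds named here.

Among the compounds with values here, in a functional assay on SiHa cells (Homo sapiens) for antiproliferative activity, read by CCK-8 assay, with a stated time of 72 h (a higher number here means a weaker inhibitor, a lower number a stronger inhibitor), compound 1 `COc1ccc(-c2cncnc2-c2cc(OC)c(OC)c(OC)c2)cc1Cl` gives 1330 nM, the second highest of the three numbers measured so far. Its nearest neighbour is compound 2 `CCOc1ccc(-c2cncnc2-c2cc(OC)c(OC)c(OC)c2)cc1Cl` at 150 nM, and the furthest is compound 3 `CCOc1ccc(-c2cncnc2-c2cc(OC)c(OC)c(OC)c2)cc1C(F)(F)F` at 20000 nM.

Compound 4 `COc1cc(-c2ncncc2-c2ccc(C(N)=O)cc2)cc(OC)c1OC` has not yet been measured. It keeps the shared core but differs at one place: 4-carbamoylphenyl in place of 3-chloro-4-methoxyphenyl on an aromatic carbon. In words, 4-carbamoylphenyl stands in place of 3-chloro-4-methoxyphenyl on an aromatic carbon.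

Within the data shown here, two measured steps touch the group that leaves, though neither replaces it whole. Methyl in place of hydrogen on the chain bound to the oxygen gave an 8.9-fold lower number from compound 1 to compound 2 (0.95 log units; beyond the scatter). Trifluoromethyl in place of chloro gave a 130-fold higher number from compound 2 to compound 3 (2.12 log units; beyond the scatter). Among these three compounds, then, single edits to this group moved the number a long way, in both directions. Compound 4 carries no chloro, and neither does compound 3, so the upward step is taken as the closer guide. Among the measured compounds shown here, no measured compound carries the carbamoyl group, which leaves the size uncertain.

A higher number is expected, with an estimated 4.5-fold higher number from compound 1 to compound 4 (0.65 log units; beyond the scatter). For compound 4 the estimated value is 6000 nM, within a range of 700 nM to 30000 nM.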

Compound 4, half-maximal inhibitory concentration: > 100000 nM
Compound 4: no number, only a limit; the forecaster's own chance of this, stated with the estimate: 15%; at least 16-fold (1.22 log units) between middle value and limit.
By their numbers in this assay, from the lowest: compound 2; then compound 1; then compound 3. At a limit, above all of these: compound 4.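

In this assay, exchanging the whole 3-chloro-4-methoxyphenyl group for 4-carbamoylphenyl gives an at least 75-fold higher number from compound 1 to compound 4 (1.87 log units; beyond the scatter), a step read against a limit. Compound 4 has no number in this assay, only a limit: the limit of > 100000 nM in this assay, at which 1 of the 4 values shown sits. The earlier steps shown here changed one part of the leaving group at a time, whereas this one shows that activity can fall out of the measurable range when the whole group is exchanged, even though the two groups have the same count of heavy atoms and the same six-membered carbon ring, and the entering group adds a hydrogen-bond donor.

This single exchange removes the chloro and the methoxy and brings in the carbamoyl all at once, so the compounds shown cannot tell which of these edits accounts for the loss. Also open, going by these compounds, is how a 4-substituted phenyl ring at this position would read with a carboxylic acid, an amine or a nitrile in place of the carbamoyl, or with the carbamoyl alongside the chloro and a methoxy.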